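The source may hold more compounds than are shown below. What is called first, only, known or untested is meant among the compounds shown, and "the series" means these compounds.

Compound 1 `CNc1ncc2c(-c3ccc(N4CCNCC4)nc3)nn(CC3CCCC3)c2n1` in an assay for inhibition of proto-oncogene tyrosine-protein kinase receptor Ret (Homo sapiens), read by 33P incorporation, in the presence of a further agent that is not named here; a lower number here means a stronger inhibitor, a higher number a weaker inhibitor: 50 nM
Compound 2 `CNc1ncc2c(-c3ccc(N4CCNCC4)nc3)nn(CC3OCCO3)c2n1` in this assay: 160 nM
Compound 3 `CNc1ncc2c(-c3ccc(OC)cc3)nn(CC3OCCO3)c2n1` in this assay: 1200 nM

Among these three numbers compound 2 stands second highest. For the measured compounds named here, compound 1 lies nearest to it, and the one step joining them, a 3.2-fold higher number from compound 1 to compound 2 (0.51 log units; beyond the scatter), is the only single-point change in the set. Compound 3 differs from compound 2 in more than one place, so its value serves only as a further reference point: compound 3 gives 1200 nM, whereas compound 2 gives 160 nM.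

Compound 4 `CNc1ncc2c(-c3ccc(N4CCNCC4)nc3)nn(Cc3cn(Cc4ccccc4)nn3)c2n1` has not yet been measured. It arises from compound 2 through the change (1-benzyl-1H-1,2,3-triazol-4-yl in place of 1,3-dioxolan-2-yl on a saturated chain carbon bound to an aromatic nitrogen). Going by the values given here, only one measured step bears on this position, a 3.2-fold higher number from compound 1 to compound 2 (0.51 log units; beyond the scatter), which shows that what sits on this saturated chain carbon does move the number in this assay, though only modestly. Neither the triazole nor the benzyl group occurs anywhere among the measured compounds, so nothing shows which way this particular group will pull. On that basis compound 4 is expected to give a number of the same order as compound 2, with the step of a 1.1-fold lower number from compound 2 to compound 4 (0.03 log units; within the scatter) taken as the estimate and a wide range on either side. The estimate for compound 4 is 150 nM, between 40 nM and 600 nM.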

Compound 4, half-maximal inhibitory concentration: 600 nM
Beside the measured number, compound 4's estimate is 4.0-fold (0.60 log units) below it; the measured number falls inside the stated range.
By their numbers in this assay, from the lowest: compound 1; then compound 2; then compounds 4 and 3 (each within the scatter of the next).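

In this assay, for the compounds shown here, the saturated chain carbon bound to an aromatic nitrogen proves more sensitive than the earlier pair could show: 1-benzyl-1H-1,2,3-triazol-4-yl in place of 1,3-dioxolan-2-yl gives a 3.8-fold higher number from compound 2 to compound 4 (0.57 log units; beyond the scatter), and the same group in place of cyclopentyl gives a 12-fold higher number from compound 1 to compound 4 (1.08 log units; beyond the scatter), the first large step at this position. From the lowest number to the highest, the three groups at this place run cyclopentyl, 1,3-dioxolan-2-yl, 1-benzyl-1H-1,2,3-triazol-4-yl, so neither replacement of cyclopentyl in these compounds lowers the number. No measurement available here gives a reason for these steps.

The triazole and the benzyl group enter together, so it remains open which of them accounts for the rise, and a 1H-1,2,3-triazol-4-yl bearing only a methyl group would help to separate the two. Also open is whether an amine or a carboxylic acid at this place would bring the number below that of compound 1 50 nM, or would leave it higher, as both heterocyclic groups shown here do.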